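A Pyridin-3-yl Ring Replaces Furan on the Carbonyl

The source may report more compounds than this note shows. Statements on the series, on what has been measured and on what is new or still open speak of the compounds shown alone.

Among the compounds with values here, compound 2 `COc1ccc(/C=C/C(=O)c2ccco2)c(CN2CCCCC2)c1O` gives 0.47 ug/mL in a functional assay on MCF7 cells (Homo sapiens) for cytotoxicity, read by sulforhodamine B assay, with a stated time of 3 days (on this read-out higher numbers stand for an effect only at larger amounts of compound and lower numbers for an effect already at smaller amounts), the highest of the two numbers measured so far, compound 1 `COc1ccc(/C=C/C(=O)c2cccs2)c(CN2CCCCC2)c1O` giving 0.11 ug/mL. Compound 3 `COc1ccc(/C=C/C(=O)c2cccnc2)c(CN2CCCCC2)c1O` differs from compound 2 by pyridin-3-yl in place of furan-2-yl on a carbonyl carbon. Within the data shown here, only one measured step concerns the ring on that carbonyl carbon: a 4.3-fold higher number from compound 1 to compound 2 (0.63 log units; beyond the scatter). Among the measured compounds shown here, no measured step covers a pyridine in that place, so the direction is open; a modest step of either sign is expected, a 1.2-fold lower number from compound 2 to compound 3 (0.07 log units; within the scatter). Compound 3 is therefore estimated at 0.4 ug/mL, within 0.1 ug/mL to 1.5 ug/mL.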

Compound 3, half-maximal effective concentration: 0.3 ug/mL
For compound 3 the middle estimate is 1.3-fold (0.12 log units) above the measured one; the measured number falls inside the stated range.
By their numbers in this assay, from the lowest: compound 1; then compounds 3 and 2 (each within the scatter of the next).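

On the carbonyl carbon, a six-membered aromatic ring with one nitrogen serves as well as the five-membered furan-2-yl, with a 1.6-fold lower number from compound 2 to compound 3 (0.19 log units; within the scatter). The thiophen-2-yl compound stays apart from this one too, with a 2.7-fold higher number from compound 1 to compound 3 (0.44 log units; beyond the scatter), so among these three rings, only thiophen-2-yl gives a number set apart from the others. Nothing available explains this difference. The compounds shown leave open how a plain phenyl ring or a pyridin-4-yl ring on that carbonyl carbon would compare, and whether thiophen-2-yl would keep its lead with a morpholine in place of the piperidine.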